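Adding a Chloro Group to Compound 1

The compounds below may be only part of what the source reports. "The series", "measured", "known", "first", "only" and "open" are said of these compounds alone.

Compound 1 `Nc1nc2cc(Cl)c(Cl)cc2n1Cc1ccc(Cl)cc1`: 45000 nM
Compound 2 `COc1ccc(Cn2c(N)nc3cc(Cl)c(Cl)cc32)cc1`: 45000 nM

In a functional assay on KB cells (Homo sapiens) for inhibition (on this read-out lower numbers stand for stronger inhibition and higher numbers for weaker inhibition), compound 1 gives 45000 nM, which puts it level with compound 2. Compound 3 `Nc1nc2cc(Cl)c(Cl)cc2n1Cc1ccc(Cl)c(Cl)c1` has not been measured yet. It differs from compound 1 in one place: chloro in place of hydrogen on an aromatic carbon. The new chloro sits on an aromatic carbon, ortho to a chloro group and meta to a large group.

Among the compounds with values here, only one measured step is available as a guide: no change at the digits printed from compound 1 to compound 2 (within the scatter), with methoxy in place of chloro on an aromatic carbon. Within the data shown here, that is a different change from the one in compound 3, so the guidance is thin. Even so, no step beyond the scatter is expected in this assay. The expected step is a 1.1-fold lower number from compound 1 to compound 3 (0.05 log units; within the scatter). Compound 3 is estimated at 40000 nM, with an expected range from 18000 nM to 90000 nM.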

Compound 3, half-maximal inhibitory concentration: 35000 nM
Compound 3: middle estimate off by 1.1-fold (0.06 log units), on the high side; measured number inside the range.
By their numbers in this assay, from the lowest: compounds 3, 1 and 2 (each within the scatter of the next).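

Putting a chloro group in place of hydrogen on this aromatic carbon, ortho to a chloro group and meta to a large group, gives a 1.3-fold lower number from compound 1 to compound 3 (0.11 log units; within the scatter) in this assay. Within the data shown here, the earlier pair showed only one group swapped for another on a carbon that already carried a substituent, whereas this step adds a group at a carbon that carried only hydrogen. In this assay, the added chloro group leaves the number within the scatter of compound 1, and nothing measured here bears on the reason for that result.

Going by these compounds, it remains open whether a different group at this position, such as an amine or a carboxylic acid, would move the number beyond the scatter. The compounds shown also leave open whether any change at this position can do so in either direction.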